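A few compounds are considered here, and "the series" means these few. Any claim that something is new, unique, unknown or untested is made for them only; others in the source may bear on it.

Measured compounds:
compound 1 `CC(C)n1nc(-c2cc(C(C)(C)C)on2)c2c(N)ncnc21`, 2100 nM
compound 2 `CC(C)(O)Cn1nc(-c2cc(C3CC3)on2)c2c(N)ncnc21`, 217 nM

In an assay on isolated protein for inhibition of proto-oncogene tyrosine-protein kinase receptor Ret variant V804M (Homo sapiens), read by radiometric assay and 33P incorporation, in the presence of a further agent that is not named here (a higher number here means a weaker inhibitor, a lower number a stronger inhibitor), compound 2 gives 217 nM, the lowest of the two numbers; compound 1 gives 2100 nM, a gap beyond the scatter, but these two structures differ in two places, so no single step can be read from the pair. Compound 3 `Cn1nc(-c2cc(C3CC3)on2)c2c(N)ncnc21` is not yet measured; it differs from compound 2 by hydrogen in place of 1-hydroxy-1-methylethyl on a saturated chain carbon bound to an aromatic nitrogen. For the measured compounds named here, no measured pair isolates this change. The step is expected to weaken inhibition, a 3.0-fold higher number from compound 2 to compound 3 (0.48 log units; beyond the scatter), with wide uncertainty. Compound 3 is expected at 650 nM, range 150 nM to 2800 nM.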

Compound 3, half-maximal inhibitory concentration: 182 nM
Beside the measured number, compound 3's estimate is 3.6-fold (0.55 log units) above it, within the range that was stated.
By their numbers in this assay, from the lowest: compounds 3 and 2 (each within the scatter of the next); then compound 1.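

In this assay, for the compounds shown here, replacing 1-hydroxy-1-methylethyl with hydrogen on a saturated chain carbon bound to an aromatic nitrogen gives a 1.2-fold lower number from compound 2 to compound 3 (0.08 log units; within the scatter) as the only single-place step. At this position, 2-hydroxy-2-methylpropyl and methyl are not distinguished by this read-out, so the hydroxy-bearing chain is not required for the level of inhibition seen with compound 2. No supporting data explain this result.

As far as these compounds go, whether an amine or a carboxylic acid at the end of a longer chain would also leave the number unchanged remains open.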